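A Methoxycarbonyl Anilide in a Fatty Acid Transporter Series

A few compounds are considered here, and "the series" means these few. Any claim that something is new, unique, unknown or untested is made for them only; others in the source may bear on it.

Measured so far:
compound 1, `CCn1c(CNc2ccccc2)nnc1SCC(=O)Nc1ccccc1`: > 1000 nM
compound 2, `CCC(=O)c1ccc2oc(CS(=O)(=O)c3nnc(CNc4ccccc4)n3CC)nc2c1`: 1670 nM
compound 3, `CCn1c(CNc2ccccc2)nnc1SCc1nc2cc(C(=O)C(C)C)ccc2o1`: 600 nM

Of the compounds shown here, three sharing the same core have been tested in an assay on isolated protein for inhibition of long-chain fatty acid transport protein 1 (Homo sapiens); on this read-out higher numbers stand for weaker inhibition and lower numbers for stronger inhibition. Compound 1 gives no number there but only a limit, > 1000 nM, which is the limit of > 1000 nM in this assay, at which 1 of the 3 values shown sits. Compound 2 gives 1670 nM in this assay and compound 3 gives 600 nM. For the measured compounds named here, neither compound 2 nor compound 3 differs from compound 1 in a single place, so no step between any two of them can be followed; their values show only that none of the three is a strong inhibitor.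

Compound 4, `CCn1c(CNc2ccccc2)nnc1SCC(=O)Nc1ccc(C(=O)OC)cc1`, has not yet been measured. It differs from compound 1 by methoxycarbonyl in place of hydrogen on an aromatic carbon. With compound 1 known only as a limit, the step from compound 1 to compound 4 is expected to be small and within the scatter, a step that the limit leaves unreadable from compound 1 to compound 4, in no clear direction. Compound 4 is therefore estimated at 2000 nM in this assay, with a range from 600 nM to 8000 nM.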

Compound 4, half-maximal inhibitory concentration: 540 nM
The estimate for compound 4 lay 3.7-fold (0.57 log units) above the measured number; the measured number lies below the stated range.
By their numbers in this assay, from the lowest: compounds 4 and 3 (each within the scatter of the next); then compound 2.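

In this assay, methoxycarbonyl in place of hydrogen on an aromatic carbon, para to a large group, gives an at least 1.8-fold lower number from compound 1 to compound 4 (0.26 log units; that floor lies within the scatter). For the compounds shown here, this is the first step that can be followed at all, and it shows that this place on the ring can carry methoxycarbonyl with a measured number in the range of the best value shown so far, not a limit. Compound 1 stands only at a limit, and the step can be given only as a floor because of that limit: the limit of > 1000 nM in this assay, at which 1 of the 4 values shown sits.

The compounds shown leave open whether the true step lies beyond the scatter. They also leave open how a carboxylic acid, a primary amide or the longer ethoxycarbonyl at the same place would read in this assay.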